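Extending the Ester Chain of Compound 2

The compounds below may be only part of what the source reports. "The series", "measured", "known", "first", "only" and "open" are said of these compounds alone.

In an ADME assay on Vero cells (Chlorocebus sabaeus) for cytotoxicity, read by MTT assay, with a stated time of 24 h (on this read-out lower numbers stand for higher toxicity in this test and higher numbers for lower toxicity in this test), compound 1 (`CCCCOC(=O)CCc1ccc(O)c(O)c1`) gives 200 ug/mL and compound 2 (`CCC(=O)OCCc1ccc(O)c(O)c1`) gives 40 ug/mL, the lower of the two numbers and beyond the scatter. Compound 3 (`CCCCC(=O)OCCc1ccc(O)c(O)c1`) differs from compound 2 by one change (ethyl in place of hydrogen on a saturated chain carbon, two bonds along the chain from a carbonyl carbon): ethyl in place of hydrogen on a saturated chain carbon, two bonds along the chain from a carbonyl carbon. Within the data shown here, no measured pair shows this change alone, so no shift beyond the scatter is expected in this assay here. The estimated step (a 1.3-fold higher number from compound 2 to compound 3 (0.10 log units; within the scatter)) is a slight rise at most. Compound 3 is expected at 50 ug/mL (range 15 ug/mL to 130 ug/mL).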

Compound 3, half-maximal cytotoxic concentration: 25 ug/mL
Compound 3: middle estimate off by 2.0-fold (0.30 log units), on the high side; the range from low to high includes it.
By their numbers in this assay, from the lowest: compounds 3 and 2 (each within the scatter of the next); then compound 1.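

Among these compounds, the pair compound 2 and compound 3 is the first direct reading of this change: ethyl in place of hydrogen on a saturated chain carbon, two bonds along the chain from a carbonyl carbon, gives a 1.6-fold lower number from compound 2 to compound 3 (0.20 log units; within the scatter) in this assay. This position therefore takes the ethyl without a shift beyond the scatter in this test. From the compounds shown here alone, whether a longer chain or an amine at this place would move the number beyond the scatter remains open. Nothing available bears on the reason for this result.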